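The compounds below may be only part of what the source reports. "The series", "measured", "known", "first", "only" and "open" are said of these compounds alone.

Three measured compounds share one core. Compound 1 `CCCCNc1nc(N)nc2c1CN(Cc1cccc(Cl)c1Cl)CC2` gives 0.18 uM in an assay on HEK293 cells for agonist activity at Toll-like receptor 8 (Homo sapiens), read by a luciferase reporter, with a stated time of 6 h (on this read-out higher numbers stand for an effect only at larger amounts of compound and lower numbers for an effect already at smaller amounts), compound 2 `CCCCNc1nc(N)nc2c1CN(Cc1c(Cl)cccc1Cl)CC2` gives 0.14 uM in this assay, and compound 3 `CCCCNc1nc(N)nc2c1CN(Cc1ccncc1)CC2` gives 0.29 uM in this assay. Compound 3 holds the highest of the three numbers: a 1.6-fold higher number from compound 1 to compound 3 (0.21 log units; within the scatter), and a 2.1-fold higher number from compound 2 to compound 3 (0.32 log units; beyond the scatter). Compound 4 `CCCCNc1nc(N)nc2c1CN(C(=O)c1csc(N)n1)CC2` differs from compound 3 in one place: (2-amino-1,3-thiazol-4-yl)carbonyl in place of (pyridin-4-yl)methyl on an amine nitrogen in a ring. The measured steps, a 1.3-fold lower number from compound 1 to compound 2 (0.11 log units; within the scatter) among them, all swap one aromatic ring for another on a saturated chain carbon; none exchanges that carbon for a carbonyl, so they bear only loosely on this change, and all were small. In this assay compound 4 is expected to give 1 uM, within 0.2 uM to 5 uM. The estimate amounts to a 3.4-fold higher number from compound 3 to compound 4 (0.54 log units; beyond the scatter).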

Compound 4, minimum effective concentration: 6.9 uM
Beside the measured number, compound 4's estimate is 6.9-fold (0.84 log units) below it, and the stated range ends below it.
By their numbers in this assay, from the lowest: compounds 2, 1 and 3 (each within the scatter of the next, the first and the last beyond it); then compound 4.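

Changing the group on this amine nitrogen in a ring can matter far more than the earlier aromatic swaps suggested: (2-amino-1,3-thiazol-4-yl)carbonyl in place of (pyridin-4-yl)methyl gives a 24-fold higher number from compound 3 to compound 4 (1.38 log units; beyond the scatter) in this assay and is the largest step seen here. Nothing measured here accounts for this loss. The step replaces both the saturated chain carbon with a carbonyl and one aromatic ring with another, so the two changes cannot be told apart. A (2-amino-1,3-thiazol-4-yl)methyl group or a (pyridin-4-yl)carbonyl group at this nitrogen would separate them.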